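The compounds below may be only part of what the source reports. "The series", "measured", "known", "first", "only" and "open" are said of these compounds alone.

Measured in a functional assay on NCI-H460 cells (Homo sapiens) for cytotoxicity, read by MTT assay, with a stated time of 48 h; a higher number here means a weaker inhibitor, a lower number a stronger inhibitor:
Compound 1 `C=C1C(=O)O[C@H]2CC3=C[C@H](C/C(C)=C/[C@@H](OC(=O)c4ccc(C(F)(F)F)cc4)[C@H]12)OC3=O`: > 10000 nM, a limit.
Compound 2 `C=C1C(=O)O[C@H]2CC3=C[C@H](C/C(C)=C/[C@@H](OC(=O)/C=C/c4ccccc4)[C@H]12)OC3=O`: > 10000 nM, a limit.
Compound 3 `C=C1C(=O)O[C@H]2CC3=C[C@H](C/C(C)=C/[C@@H](OC(=O)/C=C/c4ccc(N(C)C)cc4)[C@H]12)OC3=O`: 1300 nM.

Compound 3 is the only one of the three with an actual number, at 1300 nM. The other two sit at the limit of the measurement. The next compound, compound 4 `C=C1C(=O)O[C@H]2CC3=C[C@H](C/C(C)=C/[C@@H](OC(=O)/C=C/c4ccc(C(F)(F)F)cc4)[C@H]12)OC3=O`, has trifluoromethyl in place of dimethylamino on an aromatic carbon, para to a large group: trifluoromethyl in place of dimethylamino on an aromatic carbon.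

The closest measured change is an at least 7.6-fold lower number from compound 2 to compound 3 (0.88 log units; beyond the scatter), with dimethylamino in place of hydrogen on an aromatic carbon. Among the compounds with values here, a second change, an at least 7.6-fold lower number from compound 1 to compound 3 (0.88 log units; beyond the scatter), also ends at the one compound carrying dimethylamino. The third, a step that the two limits leave unreadable from compound 1 to compound 2, says little here. Compound 4 lacks dimethylamino, so a higher number is expected in this assay, of a size at least comparable to these two readable steps, and the assay may well report only a limit.

The expected change is a 6.9-fold higher number from compound 3 to compound 4 (0.84 log units; beyond the scatter). The estimate for compound 4 is 9000 nM, within an estimated range from 2500 nM to 30000 nM.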

Compound 4, half-maximal inhibitory concentration: 1400 nM
Compound 4: middle estimate off by 6.4-fold (0.81 log units), on the high side; measured number below the stated range.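

In this assay, within the data shown here, dimethylamino had been the only group on this aromatic carbon tied to a measured number, and the result shows that the activity does not depend on it: exchanging it for trifluoromethyl gives a 1.1-fold higher number from compound 3 to compound 4 (0.03 log units; within the scatter), so the two groups cannot be told apart here. Placing trifluoromethyl where hydrogen stood gives an at least 7.1-fold lower number from compound 2 to compound 4 (0.85 log units; beyond the scatter), which shows that a second and quite different group brings the same kind of step at this position. That step is a bound and not a full size: the limit of > 10000 nM in this assay, at which 2 of the 4 values shown sit.

As far as these compounds go, whether a methoxy group, a nitrile or a chlorine on the same aromatic carbon would behave like these two groups remains open. Also open, from the compounds shown here alone, is how far compound 2 really lies from the others, since its value is only a limit.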